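Methylation of the ring amine: compound 2 to compound 3

A few compounds are considered here, and "the series" means these few. Any claim that something is new, unique, unknown or untested is made for them only; others in the source may bear on it.

Compound 1 `O=S(=O)(c1cccc(F)c1)c1cn(C2CCCNC2)c2ccccc12` gives 6 nM in an assay on HeLa cells for displacement of a labelled ligand from 5-hydroxytryptamine receptor 6 (Homo sapiens), with a stated time of 2 h; on this read-out lower numbers stand for stronger inhibition and higher numbers for weaker inhibition.
Compound 2 `O=S(=O)(c1cccc(F)c1)c1cn(C2CCNC2)c2ccccc12` gives 4.7 nM in this assay.

Compound 2 holds the lower of the two numbers, yet the step of a 1.3-fold lower number from compound 1 to compound 2 (0.11 log units; within the scatter) is within the scatter, so compound 2 and compound 1 stand side by side on this read-out rather than in any order. Compound 3 `CN1CCC(n2cc(S(=O)(=O)c3cccc(F)c3)c3ccccc32)C1` differs from compound 2 by methyl in place of hydrogen on an amine nitrogen in a ring. Within the data shown here, the single measured step, from compound 1 to compound 2, swaps one saturated ring for another and keeps the amine hydrogen; it says nothing about adding a methyl to that nitrogen, and it is itself within the scatter. Among the measured compounds shown here, no measured step therefore bears on the change. With no anchor for direction, a step no larger than the usual scatter is expected in this assay, with some allowance toward weaker inhibition. Compound 3 is estimated at 8 nM, with a range of 3 nM to 25 nM, which corresponds to an expected step of a 1.7-fold higher number from compound 2 to compound 3 (0.23 log units; within the scatter).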

Compound 3, inhibition constant: 3.5 nM
Beside the measured number, compound 3's estimate is 2.3-fold (0.36 log units) above it; the measured number falls inside the stated range.
By their numbers in this assay, from the lowest: compounds 3, 2 and 1 (each within the scatter of the next).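

Methyl in place of hydrogen on the amine nitrogen in the ring stays within the scatter in this assay (a 1.3-fold lower number from compound 2 to compound 3 (0.13 log units; within the scatter)), so this pair gives no sign that the amine hydrogen is needed on this read-out. Going from piperidin-3-yl to 1-methylpyrrolidin-3-yl on the aromatic nitrogen, which changes the ring and adds the methyl, also stays within the scatter (a 1.7-fold lower number from compound 1 to compound 3 (0.23 log units; within the scatter)), so the three compounds stand side by side with no real order among them. No measurement at hand gives a reason for this outcome.

Still open, going by these compounds, is whether a larger group on this ring nitrogen, such as ethyl, benzyl or acetyl, also stays within the scatter. Equally open, on these data alone, is whether 1-methylpiperidin-3-yl on the aromatic nitrogen reads like 1-methylpyrrolidin-3-yl.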